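Ester aryl change in a cyclohexyl nitroanilide series

This account rests on a few compounds, and the source may have more. Where it says the series, first, only, none or still open, it means among the compounds named here.

Compound 1 `O=C(OC1(C(=O)Nc2ccc([N+](=O)[O-])cc2)CCCCC1)c1ccc(C(F)(F)F)cc1`: 185 nM
Compound 2 `O=C(OC1(C(=O)Nc2ccc([N+](=O)[O-])cc2)CCCCC1)c1ccc(Cl)cc1`: 355 nM
Compound 3 `COc1ccc(C(=O)OC2(C(=O)Nc3ccc([N+](=O)[O-])cc3)CCCCC2)cc1`: 40 nM

The three measured compounds share one core and differ only in the aryl group of the ester. In an ADME assay on WI-38 cells (Homo sapiens) for inhibition, read by MTT assay, with a stated time of 72 h (a lower number here means a stronger inhibitor, a higher number a weaker inhibitor), compound 1 gives 185 nM, the second highest of the three numbers; the nearest is a 1.9-fold higher number from compound 1 to compound 2 (0.28 log units; within the scatter), the furthest is a 4.6-fold lower number from compound 1 to compound 3 (0.67 log units; beyond the scatter). The remaining measured step is an 8.9-fold lower number from compound 2 to compound 3 (0.95 log units; beyond the scatter).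

Compound 4 `Cc1ccccc1C(=O)OC1(C(=O)Nc2ccc([N+](=O)[O-])cc2)CCCCC1` differs from compound 1 in that (2-methylphenyl in place of 4-(trifluoromethyl)phenyl on a carbonyl carbon). Among the compounds with values here, none of the measured steps matches this change: each of them swaps one group at the same place on the aryl ring, whereas here both the group and its place on the ring change. The steps from compound 1 to compound 2 and from compound 2 to compound 3 only show that changes at this aryl group move the number by a modest amount in either direction. On this basis compound 4 is expected to stay near compound 1, with a step of about a 1.4-fold higher number from compound 1 to compound 4 (0.13 log units; within the scatter), and the estimate for compound 4 in this assay is 250 nM, expected to lie between 80 nM and 800 nM.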

Compound 4, half-maximal inhibitory concentration: 352 nM
Beside the measured number, compound 4's estimate is 1.4-fold (0.15 log units) below it; the range from low to high includes it.
By their numbers in this assay, from the lowest: compound 3; then compounds 1, 4 and 2 (each within the scatter of the next).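

In this assay, the step of a 1.9-fold higher number from compound 1 to compound 4 (0.28 log units; within the scatter) and the step of a 1.0-fold lower number from compound 2 to compound 4 (0.00 log units; within the scatter) both lie within the scatter, so the 2-methylphenyl ester sits with the 4-(trifluoromethyl)phenyl and 4-chlorophenyl esters. The step of an 8.8-fold higher number from compound 3 to compound 4 (0.94 log units; beyond the scatter) lies beyond the scatter, which shows that an aryl group without fluorine or chlorine does not by that alone reach the low number of compound 3, and the 4-methoxyphenyl ester stays the only one of the four aryl groups that stands apart. No measurement offered here explains why compound 4 groups with compound 1 and compound 2 rather than with compound 3.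

Because compound 4 changes the group and its place together, the compounds shown cannot separate these two changes. On these data alone, it also remains open what a 2-methoxyphenyl ester, or an amine or carboxylic acid on the aryl ring, would give.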